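Compound 4: removing the ring methyl from compound 3

The source may hold more compounds than are shown below. What is called first, only, known or untested is meant among the compounds shown, and "the series" means these compounds.

Measured so far in an assay on HEK293 cells for displacement of a labelled ligand from Melanocortin receptor 4 (Homo sapiens); a lower number here means a stronger inhibitor, a higher number a weaker inhibitor:
- compound 1 `CC(C)C[C@H](N)c1cc(C(F)(F)F)ccc1N1CCN(C(=O)COc2ccc(O)cc2)CC1` gives 4600 nM
- compound 2 `CC(C)C[C@H](N)c1cc(C(F)(F)F)ccc1N1CCN(C(=O)CCC2CCCCC2)CC1` gives 5700 nM
- compound 3 `Cc1cc(CC(C)C(=O)N2CCN(c3ccc(C(F)(F)F)cc3[C@@H](N)CC(C)C)CC2)ccc1Cl` gives 71 nM

Compound 3 has the lowest number of the three. Its separation from compound 1 is a 65-fold lower number from compound 1 to compound 3 (1.81 log units; beyond the scatter) and from compound 2 an 80-fold lower number from compound 2 to compound 3 (1.90 log units; beyond the scatter), both well beyond the scatter, so compound 3 is the strongest inhibitor in this set. Compound 1 and compound 2 sit within the scatter of each other, a 1.2-fold higher number from compound 1 to compound 2 (0.09 log units; within the scatter), so nothing is said about their order.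

Compound 4 `CC(C)C[C@H](N)c1cc(C(F)(F)F)ccc1N1CCN(C(=O)C(C)Cc2ccc(Cl)cc2)CC1` differs from compound 3 by hydrogen in place of methyl on an aromatic carbon, that is, 4-chloro-3-methylbenzyl to 4-chlorobenzyl on the amide side chain. Going by the values given here, none of the measured steps removes a methyl from an aromatic ring; the two large steps into compound 3 exchange the whole side chain, so they show only that this side chain carries most of the gain, not what the methyl alone contributes. The expected step is therefore small, somewhat in the direction of a higher number, estimated as a 2.1-fold higher number from compound 3 to compound 4 (0.32 log units; beyond the scatter). For compound 4 the number in this assay is expected to be about 150 nM, with a range of 50 nM to 500 nM.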

Compound 4, inhibition constant: 47 nM
Compound 4: the middle estimate sits 3.2-fold (0.50 log units) above what was measured; the measured number lies below the stated range.
By their numbers in this assay, from the lowest: compounds 4 and 3 (each within the scatter of the next); then compounds 1 and 2 (each within the scatter of the next).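

In this assay, going by these compounds alone, the first change confined to a single ring position, hydrogen in place of the methyl ortho to a chloro group, gives a 1.5-fold lower number from compound 3 to compound 4 (0.18 log units; within the scatter) and so does not separate the two compounds. The large side-chain gain therefore does not depend on the ring methyl, as 1-(4-chlorobenzyl)ethyl still gives a 120-fold lower number from compound 2 to compound 4 (2.08 log units; beyond the scatter) and a 98-fold lower number from compound 1 to compound 4 (1.99 log units; beyond the scatter) against the two weaker side chains. No measurement in hand accounts for this flat response to the methyl.

Still open, as far as these compounds go, is what the chloro group itself contributes, and how a fluoro, a methoxy or a plain hydrogen on that ring carbon would read in this assay. Also open, from the compounds shown here alone, are whether an ethyl or a methoxy group would be accepted where the methyl stood, and whether the branching methyl of the 1-(4-chlorobenzyl)ethyl chain matters, which a plain 4-chlorobenzyl or a longer chain on the carbonyl carbon would test.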